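Working notes: phenyl to 4-methylphenyl, compound 3 to compound 4

The source may report more compounds than this note shows. Statements on the series, on what has been measured and on what is new or still open speak of the compounds shown alone.

Values measured in a functional assay on thoracic aorta (Rattus norvegicus, strain Wistar), with a stated time of 15 min (on this read-out lower numbers stand for an effect already at smaller amounts and higher numbers for an effect only at larger amounts of compound), for three compounds
- compound 1 `COc1ccc(OC)c(CNC(=O)NS(=O)(=O)c2ccc(C)cc2)c1` gives > 300000 nM as a limit
- compound 2 `COc1ccc(OC)c(CNC(=O)N(C)S(=O)(=O)c2ccc(Cl)cc2)c1` gives 18200 nM
- compound 3 `COc1ccc(OC)c(CNC(=O)N(C)S(=O)(=O)c2ccccc2)c1` gives 21300 nM

Only compound 2 and compound 3 give numbers, and they stand level with each other. The measured step between them is a 1.2-fold higher number from compound 2 to compound 3 (0.07 log units; within the scatter) with hydrogen in place of chloro on an aromatic carbon.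

The next compound is compound 4 `COc1ccc(OC)c(CNC(=O)N(C)S(=O)(=O)c2ccc(C)cc2)c1` and it has not yet been measured. The change is methyl in place of hydrogen on an aromatic carbon and it places methyl in place of hydrogen on an aromatic carbon, para to a large group.

The step with chloro is the only measured one that bears on this change, and one step is thin support. Since compound 2 and compound 3 differ by a 1.2-fold higher number from compound 2 to compound 3 (0.07 log units; within the scatter) in this series, no step beyond the scatter is expected in this assay and no direction is favoured. The expected outcome is a 1.1-fold lower number from compound 3 to compound 4 (0.03 log units; within the scatter) on this estimate. For compound 4 the estimate is 20000 nM with an expected range from 9000 nM to 45000 nM in these working notes.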

Compound 4, half-maximal effective concentration: 20900 nM
Estimate against measurement, compound 4: 1.0-fold (0.02 log units) below, within the range that was stated.
By their numbers in this assay, from the lowest: compounds 2, 4 and 3 (each within the scatter of the next). At a limit, above all of these: compound 1.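

In this assay, phenyl to 4-methylphenyl gives a 1.0-fold lower number from compound 3 to compound 4 (0.01 log units; within the scatter), and methyl in place of chloro gives a 1.1-fold higher number from compound 2 to compound 4 (0.06 log units; within the scatter), so hydrogen, chloro and methyl on this aromatic carbon, para to a large group, all stand level, where the earlier compounds had shown this for hydrogen and chloro only. Going by these compounds alone, with 4-methylphenyl on both sides, methyl in place of hydrogen on the amide-type nitrogen gives an at least 14-fold lower number from compound 1 to compound 4 (1.15 log units; beyond the scatter), the first single-change comparison at that nitrogen and the only new step beyond the scatter. Compound 1 gives a limit and not a number: the limit of > 300000 nM in this assay, at which 1 of the 4 values shown sits.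

As far as these compounds go, whether an amine or a carboxylic acid at this para place would move the number beyond the scatter remains open. Also open, from the compounds shown here alone, is how a longer chain in place of methyl on the amide-type nitrogen would read in this assay.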